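Extending an amine chain from compound 3 to compound 4

The source may hold more compounds than are shown below. What is called first, only, known or untested is meant among the compounds shown, and "the series" means these compounds.

Compound 1 `CNCCCCNCCCNC` gives 1700 nM in a functional assay on L1210 cells (Mus musculus) for inhibition, with a stated time of 96 h; a higher number here means a weaker inhibitor, a lower number a stronger inhibitor
Compound 2 `CNCCCCNCCCCNC` gives 900 nM in this assay
Compound 3 `CNCCCCCNCCCCNC` gives 120 nM in this assay
Compound 4 `CNCCCCCNCCCCCNC` is still to be measured

Compound 3 holds the lowest of the three numbers, with compound 2 nearest and compound 1 furthest away. The move to compound 4 is (methylamino)methyl in place of methylamino on a saturated chain carbon, four bonds along the chain from an amine nitrogen; cut one bond further out, it reads 2-(methylamino)ethyl to 3-(methylamino)propyl.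

Among the compounds with values here, the closest precedent is a 7.5-fold lower number from compound 2 to compound 3 (0.88 log units; beyond the scatter), which is the same replacement at the same place. The same replacement at three bonds along the chain gave a 1.9-fold lower number from compound 1 to compound 2 (0.28 log units; within the scatter), and the two together amount to a 14-fold lower number from compound 1 to compound 3 (1.15 log units; beyond the scatter). Both measured replacements lowered the number, but only one lies beyond the scatter, and two steps of unequal size set no firm rule. Within the data shown here, a further modest drop is therefore expected in this assay, probably smaller than the closest precedent. The expected step is a 2.4-fold lower number from compound 3 to compound 4 (0.38 log units; beyond the scatter), an estimate only. For compound 4 the estimated value is 50 nM, with an expected range from 15 nM to 200 nM as its limits.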

Compound 4, half-maximal inhibitory concentration: 400 nM
The estimate for compound 4 lay 8.0-fold (0.90 log units) below the measured number, outside the stated range (above it).
By their numbers in this assay, from the lowest: compound 3; then compound 4; then compounds 2 and 1 (each within the scatter of the next).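

In this assay, the replacement of methylamino by (methylamino)methyl, four bonds along the chain from an amine nitrogen, turns out not to act in a single direction: it gave a 7.5-fold lower number from compound 2 to compound 3 (0.88 log units; beyond the scatter), yet it now gives a 3.3-fold higher number from compound 3 to compound 4 (0.52 log units; beyond the scatter). Extending the chain therefore stops paying off after compound 3, which, with its steps to the other three compounds all beyond the scatter, is the strongest inhibitor of the four. The outcome of this change also depends on the core that carries it, so a single step cannot be carried over to another core: the same change on two cores in this assay, a 1.9-fold lower number (0.28 log units; within the scatter) from compound 1 to compound 2 and a 3.3-fold higher number (0.52 log units; beyond the scatter) from compound 3 to compound 4, 6.3-fold (0.80 log units) apart, beyond the scatter of two such steps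

Going by these compounds, whether the number keeps rising with a still longer chain than 3-(methylamino)propyl remains open. So does the effect of a primary amine or a dimethylamino group in place of methylamino on the chain of compound 3.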